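Swapping methylsulfanyl for 3-chlorophenyl on the shared core

The source may hold more compounds than are shown below. What is called first, only, known or untested is meant among the compounds shown, and "the series" means these compounds.

Compound 1 `CCCCCCCCc1ccc(OCC(=O)Cn2nnc(SC)n2)cc1`: < 5% (a limit of the assay, not a number)
Compound 2 `CCCCCCCCc1ccc(OCC(=O)Cn2nnnc2SC)cc1`: 21%

Within the data shown here, in an ADME assay on S9 fraction from liver (Rattus norvegicus) for metabolic stability, read by LC-MS, using NADPH, with a stated time of 30 min (a higher number here means that more of the compound is left, a lower number that less of the compound is left), compound 2 holds the only actual number so far, 21%. Among the measured compounds shown here, the sole measured step is a number at least 16 percentage points higher from compound 1 to compound 2 (beyond the scatter). Its size is only a bound, since it starts from the limit of < 5% in this assay, at which 1 of the 2 values shown sits. That step keeps the methylsulfanyl group, so it bears only indirectly on what comes next.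

Compound 3 `CCCCCCCCc1ccc(OCC(=O)Cn2nnnc2-c2cccc(Cl)c2)cc1` differs from compound 2 by 3-chlorophenyl in place of methylsulfanyl on an aromatic carbon. For the measured compounds named here, no measured step covers this exchange, so the expectation rests on compound 2 at 21%. The expected change is a number 1 percentage points lower from compound 2 to compound 3 (within the scatter), which means no clear step beyond the scatter in either direction. For compound 3 the estimated value is 20%, with an expected range from 5% to 45%.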

Compound 3, percent of the compound remaining: 41%
For compound 3 the middle estimate is 21 percentage points below the measured one, within the range that was stated.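

Exchanging methylsulfanyl for 3-chlorophenyl on the aromatic carbon between two ring nitrogen atoms gives a number 20 percentage points higher from compound 2 to compound 3 (beyond the scatter) in this assay, so this position can carry a six-membered aromatic ring of carbon only with no loss in the percent of compound remaining. The earlier pair, compound 1 and compound 2, both carried methylsulfanyl, so it said nothing about the group on this carbon. Nothing given here accounts for the size of this step.

From the compounds shown here alone, whether the difference belongs to the ring, to its chlorine or to the departure of the sulfur stays open, as compound 3 changes these together. Going by these compounds, how a plain phenyl, a cyclohexyl or a morpholine on this carbon would stand in this assay also remains unknown.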